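The source may hold more compounds than are shown below. What is called first, only, known or untested is meant among the compounds shown, and "the series" means these compounds.

Measured so far:
- compound 1 `CCCCc1ccc2[nH]c(-c3ccc(C(F)(F)F)cc3)c(/C=N/NC(=O)c3ccc(OC)cc3)c2c1`: 618 nM
- compound 2 `CCCCc1ccc2[nH]c(-c3ccc(C(F)(F)F)cc3)c(/C=N/NC(=O)c3ccncc3)c2c1`: 100 nM

For the measured compounds named here, in a functional assay on MCF7 cells (Homo sapiens) for antiproliferative activity, with a stated time of 5 days (on this read-out lower numbers stand for stronger inhibition and higher numbers for weaker inhibition), compound 2 gives 100 nM, the lower of the two numbers so far. The next compound is compound 3 `CCCCc1ccc2[nH]c(-c3ccc(C(F)(F)F)cc3)c(/C=N/NC(=O)c3ccccn3)c2c1`, which differs from it as follows: pyridin-2-yl in place of pyridin-4-yl on a carbonyl carbon. In words, it has pyridin-2-yl in place of pyridin-4-yl on a carbonyl carbon.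

Going by the values given here, only one measured step bears on this change: a 6.2-fold lower number from compound 1 to compound 2 (0.79 log units; beyond the scatter). It is modest, and it came with pyridin-4-yl in place of 4-methoxyphenyl on a carbonyl carbon. So the read-out does move with the group at this place, but no measured compound carries pyridin-2-yl. A smaller step than that one is expected, leaning toward a higher number. The estimated step is a 1.8-fold higher number from compound 2 to compound 3 (0.26 log units; within the scatter). For compound 3 the estimated value is 180 nM, with an expected range of 60 nM to 550 nM.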

Compound 3, half-maximal inhibitory concentration: 310 nM
Estimate against measurement, compound 3: 1.7-fold (0.24 log units) below; measured number inside the range.
By their numbers in this assay, from the lowest: compound 2; then compounds 3 and 1 (each within the scatter of the next).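

In this assay, pyridin-2-yl and pyridin-4-yl have the same atoms joined differently, yet the change gives a 3.1-fold higher number from compound 2 to compound 3 (0.49 log units; beyond the scatter), so having a pyridine ring on this carbonyl carbon is not enough; how the ring is joined also counts. Pyridin-2-yl does not clearly keep the gain seen with pyridin-4-yl: replacing 4-methoxyphenyl with it gives a 2.0-fold lower number from compound 1 to compound 3 (0.30 log units; within the scatter), a step within the usual scatter of repeated measurements, so compound 1 and compound 3 cannot be told apart here. No measurement at hand explains why the two pyridine groups differ.

Still open is where pyridin-3-yl would fall relative to the two pyridine groups shown. An unsubstituted phenyl on the same carbonyl carbon would also show whether the methoxy group or the ring nitrogen accounts for more of these differences.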